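Swapping the aryl ketone of compound 1 for a furan

This account rests on a few compounds, and the source may have more. Where it says the series, first, only, none or still open, it means among the compounds named here.

Compound 1 `COc1cc(-c2nnc3n2NC(c2ccco2)C(C(=O)c2ccccc2C)S3)cc(OC)c1OC` is the weakest of the three measured compounds in a functional assay on PC-3 cells (Homo sapiens) for cytotoxicity, read by MTT assay, with a stated time of 48 h (a lower number here means a stronger inhibitor, a higher number a weaker inhibitor), where compound 1 gives 88400 nM. Compound 2 `COc1cc(-c2nnc3n2NC(c2ccco2)C(C(=O)c2ccc(F)cc2)S3)cc(OC)c1OC` gives 27700 nM and compound 3 `COc1cc(-c2nnc3n2NC(c2ccco2)C(C(=O)c2ccc(F)c(F)c2)S3)cc(OC)c1OC` gives 36000 nM. Both measured steps away from compound 1 lowered the number: a 3.2-fold lower number from compound 1 to compound 2 (0.50 log units; beyond the scatter) and a 2.5-fold lower number from compound 1 to compound 3 (0.39 log units; beyond the scatter), while the further change a 1.3-fold higher number from compound 2 to compound 3 (0.11 log units; within the scatter) made no difference beyond the scatter.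

Compound 4 `COc1cc(-c2nnc3n2NC(c2ccco2)C(C(=O)c2ccco2)S3)cc(OC)c1OC` is not yet measured. It differs from compound 1 at the same carbonyl carbon: furan-2-yl in place of 2-methylphenyl on a carbonyl carbon. Because the two steps of a 3.2-fold lower number from compound 1 to compound 2 (0.50 log units; beyond the scatter) and a 2.5-fold lower number from compound 1 to compound 3 (0.39 log units; beyond the scatter) both show that replacing the 2-methylphenyl at this carbonyl carbon gave a modestly lower number, a lower number is also expected for compound 4, though a furan-2-yl has not been tried there and the size is uncertain. Compound 4 is therefore expected to give about 35000 nM in this assay, within 12000 nM to 100000 nM, which would be the step of a 2.5-fold lower number from compound 1 to compound 4 (0.40 log units; beyond the scatter).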

Compound 4, half-maximal inhibitory concentration: 58300 nM
Beside the measured number, compound 4's estimate is 1.7-fold (0.22 log units) below it; measured number inside the range.
By their numbers in this assay, from the lowest: compounds 2, 3, 4 and 1 (each within the scatter of the next, the first and the last beyond it).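

In this assay, the furan-2-yl group on this carbonyl carbon cannot be told apart from the 2-methylphenyl group, with a 1.5-fold lower number from compound 1 to compound 4 (0.18 log units; within the scatter), so leaving the 2-methylphenyl group does not by itself give a step beyond the scatter. The furan-2-yl group also cannot be told apart from the 3,4-difluorophenyl group, with a 1.6-fold higher number from compound 3 to compound 4 (0.21 log units; within the scatter), yet it does stand apart from the 4-fluorophenyl group, with a 2.1-fold higher number from compound 2 to compound 4 (0.32 log units; beyond the scatter). Nothing available explains these differences.

On these data alone, what a thiophen-2-yl, a pyridin-2-yl or a 4-chlorophenyl group would give on this carbonyl carbon remains open. All four compounds share the rest of the core, so they leave open how a change anywhere else would read in this assay.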